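Changing the anilino ring of compound 3 to 4-isopropylphenyl

The compounds below may be only part of what the source reports. "The series", "measured", "known", "first", "only" and "open" are said of these compounds alone.

Measured compounds:
compound 1, `CC(C)c1ccc(-c2nc(SCc3cn(CC(=O)NC(=O)Nc4ccccn4)nn3)nc(Nc3ccccc3Cl)c2C#N)cc1`, 6790 nM
compound 2, `CC(C)c1ccc(-c2nc(SCc3cn(CC(=O)NC(=O)Nc4ccccn4)nn3)nc(Nc3cccc(C(F)(F)F)c3)c2C#N)cc1`, 1700 nM
compound 3, `CC(C)c1ccc(-c2nc(SCc3cn(CC(=O)NC(=O)Nc4ccccn4)nn3)nc(Nc3ccccc3O)c2C#N)cc1`, 16100 nM

In a functional assay on B16-F10 cells (Mus musculus) for inhibition, read by MTT assay, with a stated time of 72 h (on this read-out higher numbers stand for weaker inhibition and lower numbers for stronger inhibition), compound 3 gives the highest of the three numbers. Its nearest neighbour is compound 1, reached by a 2.4-fold higher number from compound 1 to compound 3 (0.37 log units; beyond the scatter), and its furthest is compound 2, reached by a 9.5-fold higher number from compound 2 to compound 3 (0.98 log units; beyond the scatter). Compound 4, `CC(C)c1ccc(Nc2nc(SCc3cn(CC(=O)NC(=O)Nc4ccccn4)nn3)nc(-c3ccc(C(C)C)cc3)c2C#N)cc1`, differs from compound 3 in one place: 4-isopropylphenyl in place of 2-hydroxyphenyl on a nitrogen on an aromatic ring.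

Within the data shown here, two measured steps bear on this change, since both replace the 2-hydroxyphenyl ring of compound 3 with a ring carrying no hydroxy: the step of a 9.5-fold higher number from compound 2 to compound 3 (0.98 log units; beyond the scatter), read in reverse, and the step of a 2.4-fold higher number from compound 1 to compound 3 (0.37 log units; beyond the scatter), read in reverse. Both point the same way, to a lower number when the hydroxy-bearing ring is exchanged, with the larger step belonging to the ring that carries the trifluoromethyl group. Compound 4 brings in a 4-isopropylphenyl ring with no hydrogen-bond donor or acceptor, so a step downward of modest size is expected, likely between those two measured steps.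

Compound 4 is therefore estimated at 3000 nM in this assay, within a range of 1000 nM to 9000 nM, which corresponds to an expected step of a 5.4-fold lower number from compound 3 to compound 4 (0.73 log units; beyond the scatter).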

Compound 4, half-maximal inhibitory concentration: 4380 nM
The estimate for compound 4 lay 1.5-fold (0.16 log units) below the measured number, and the stated range covers the measured number.
By their numbers in this assay, from the lowest: compound 2; then compounds 4 and 1 (each within the scatter of the next); then compound 3.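

In this assay, a 3.7-fold lower number from compound 3 to compound 4 (0.57 log units; beyond the scatter) adds a third ring without hydroxy on this nitrogen that gives a lower number than 2-hydroxyphenyl, and neither compound 1 nor compound 2 goes against this pattern among the four compounds. Removing the hydroxy is not enough to match the 3-(trifluoromethyl)phenyl ring, as a 2.6-fold higher number from compound 2 to compound 4 (0.41 log units; beyond the scatter) shows, whereas a 1.6-fold lower number from compound 1 to compound 4 (0.19 log units; within the scatter) leaves the 4-isopropylphenyl and 2-chlorophenyl rings indistinguishable in this assay. No measurement shown here accounts for these differences.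

The compounds shown leave open how this read-out would respond to an amine or a carboxylic acid on this ring, since all four rings carry only chloro, trifluoromethyl, hydroxy or isopropyl. They also do not separate the identity of a group from its place on the ring, since no single group appears at more than one place.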